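Moving the triazole attachment point on the shared core

The source may report more compounds than this note shows. Statements on the series, on what has been measured and on what is new or still open speak of the compounds shown alone.

Compound 2 `Cc1cc(C)c(NC(=O)N(Cc2ccc(-n3ccnn3)cc2)C2CCCCCC2)c(C)c1` carries a 1H-1,2,3-triazol-1-yl group on the shared core. In a functional assay on a cell-free system (plasma) with sterol O-acyltransferase, Soat (Rattus norvegicus) as the target (a higher number here means that more compound is needed for the effect, a lower number that less compound is needed), compound 2 gives > 1 mg/kg, which is a limit of the assay rather than a number. Compound 1 `Cc1cc(C)c(NC(=O)N(Cc2ccc(-c3cn[nH]c3)cc2)C2CCCCCC2)c(C)c1` gives > 1 mg/kg in this assay, again only a limit. The step that the two limits leave unreadable from compound 1 to compound 2 therefore cannot be read, and the limit of > 1 mg/kg in this assay, at which 2 of the 2 values shown sit, shows that both known values rest at the same limit. Compound 3 `Cc1cc(C)c(NC(=O)N(Cc2ccc(-n3nccn3)cc2)C2CCCCCC2)c(C)c1` has not yet been measured; it differs from compound 2 in one place: 2H-1,2,3-triazol-2-yl in place of 1H-1,2,3-triazol-1-yl on an aromatic carbon. For the measured compounds named here, no measured step bears on this change, and the two known values give neither size nor direction. The expectation for compound 3 is therefore a result near the same limit, with the step that the limit leaves unreadable from compound 2 to compound 3 expected to stay within the scatter. Compound 3 is estimated at 2 mg/kg, with a range from 0.7 mg/kg to 6 mg/kg.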

Compound 3, dose for half-maximal effect: > 1 mg/kg
Compound 3 was reported as a limit; the forecaster's own chance of this, stated with the estimate: 75%; the middle value is on the limit's open side.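

Compound 3 also gives only a limit in this assay, so no step among compound 1, compound 2 and compound 3 can be read: the limit of > 1 mg/kg in this assay, at which 3 of the 3 values shown sit.

The compounds shown leave open whether 2H-1,2,3-triazol-2-yl and 1H-1,2,3-triazol-1-yl differ at all in the dose needed.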